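Extending a short chain on weakly cytotoxic sulfonate ureas

A few compounds are considered here, and "the series" means these few. Any claim that something is new, unique, unknown or untested is made for them only; others in the source may bear on it.

Of the compounds shown here, three have been tested in a functional assay on M21 cells (Homo sapiens) for cytotoxicity, read by sulforhodamine B assay, with a stated time of 48 h; on this read-out lower numbers stand for stronger inhibition and higher numbers for weaker inhibition. Compound 1 `CCc1ccccc1OS(=O)(=O)c1ccc(NC(=O)NCCCCl)cc1` gives 15000 nM. Compound 2 `CCCc1ccccc1OS(=O)(=O)c1ccc(NC(=O)NCCCCl)cc1` gives 13000 nM in this assay. Compound 3 `CCNC(=O)Nc1cccc(S(=O)(=O)Oc2ccccc2CC)c1` gives 30000 nM in this assay, the highest of the three numbers, though its gap to compound 1 is within the scatter and only its gap to compound 2 lies beyond it. The difference between the core of compound 3 and the core of compound 1 is not broken down here.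

The change from compound 1 to compound 2 is methyl in place of hydrogen on a saturated chain carbon, two bonds along the chain from an aromatic carbon. It produced a 1.2-fold lower number from compound 1 to compound 2 (0.06 log units; within the scatter), a step too small to count as a real gain.

Compound 4 `CCCc1ccccc1OS(=O)(=O)c1cccc(NC(=O)NCC)c1` has not yet been measured. It arises from compound 3 by methyl in place of hydrogen on a saturated chain carbon, two bonds along the chain from an aromatic carbon, which is the same change, made on a different core. Within the data shown here, since the one measured example of this change, from compound 1 to compound 2, left the number essentially where it was, the expectation for compound 4 in this assay is a similarly small step, a 1.2-fold lower number from compound 3 to compound 4 (0.08 log units; within the scatter), resting only on that single precedent and on the value of compound 3, 30000 nM. Compound 4 is therefore estimated at 25000 nM in this assay, with a likely range from 10000 nM to 60000 nM, because compound 3 sits at 30000 nM and the change is not expected to move it far.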

Compound 4, half-maximal inhibitory concentration: 25000 nM
Estimate against measurement, compound 4: no gap at the digits printed; the range from low to high includes it.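

In this assay, going from ethyl to propyl on the core of compound 3 gives a 1.2-fold lower number from compound 3 to compound 4 (0.08 log units; within the scatter), and this step agrees with the one seen on the other core: the same change on two cores in this assay, a 1.2-fold lower number (0.06 log units; within the scatter) from compound 1 to compound 2 and a 1.2-fold lower number (0.08 log units; within the scatter) from compound 3 to compound 4, 1.0-fold (0.02 log units) apart, within the scatter of two such steps On these two cores, then, the change carries over cleanly: neither step moves the number by more than ordinary repeat measurements would, and the core does not visibly alter the outcome. This does not show that the chain length is unimportant across the whole series or that the same would hold on a third core, as the finding rests on just two pairs of compounds, and two steps that are both within the scatter show only that no effect was detected here, not what lies behind that.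

The compounds shown carry only ethyl and propyl at this place, so it remains open whether a longer chain, a branched chain or a ring would shift the number beyond the scatter. From the compounds shown here alone, it is equally open whether a more different group there, such as an amine or a carboxylic acid, would change the cytotoxicity of these weakly active compounds in either direction.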